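Phenoxy replacing trifluoromethyl in a cytotoxicity series

The compounds below may be only part of what the source reports. "The series", "measured", "known", "first", "only" and "open" are said of these compounds alone.

Measured compounds:
compound 1 `CC1(C)CC(=O)C2=C(C1)OC(N)=C(C#N)C2c1cccc(C(F)(F)F)c1`: 388 ug/mL
compound 2 `CC1(C)CC(=O)C2=C(C1)OC(N)=C(C#N)C2c1ccccc1C#N`: 414 ug/mL
compound 3 `O=c1oc2ccccc2c(O)c1C(c1ccc(F)c(Cl)c1)c1c(O)c2ccccc2oc1=O`: 32.6 ug/mL

In a functional assay on HuTu80 cells (Homo sapiens) for cytotoxicity, read by MTT assay, with a stated time of 48 h (on this read-out higher numbers stand for weaker inhibition and lower numbers for stronger inhibition), compound 1 gives 388 ug/mL, the second highest of the three numbers. Compound 2 gives 414 ug/mL, which lies within the usual scatter of compound 1, so the two cannot be told apart. Compound 3, built on a different core, gives 32.6 ug/mL, a lower number that lies beyond the scatter.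

Compound 4 `CC1(C)CC(=O)C2=C(C1)OC(N)=C(C#N)C2c1cccc(Oc2ccccc2)c1` shares the core of compound 1 and differs only in one place: phenoxy in place of trifluoromethyl on an aromatic carbon. Going by the values given here, no measured pair in this set shows what such a change does, so compound 4 is expected to stay near compound 1, with the step of a 1.1-fold lower number from compound 1 to compound 4 (0.04 log units; within the scatter) estimated as none beyond the scatter. In this assay compound 4 is therefore estimated at 350 ug/mL, within a range from 150 ug/mL to 800 ug/mL.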

Compound 4, half-maximal inhibitory concentration: 900 ug/mL
Compound 4: middle estimate off by 2.6-fold (0.41 log units), on the low side; measured number above the stated range.
By their numbers in this assay, from the lowest: compound 3; then compounds 1 and 2 (each within the scatter of the next); then compound 4.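

In this assay, going by these compounds alone, the change to phenoxy in place of trifluoromethyl on an aromatic carbon gives a 2.3-fold higher number from compound 1 to compound 4 (0.37 log units; beyond the scatter) and is the first single-place comparison on the shared core. It shows that this position responds to the group it carries, with phenoxy here going with weaker inhibition. No measurement at hand explains this rise. Still open, going by these compounds, is how an amine, a methoxy group or a lone fluorine at this place would compare. One pair also cannot show whether the same change acts alike on other cores.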